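Fluoro in place of chloro on compound 2

The compounds below may be only part of what the source reports. "The series", "measured", "known", "first", "only" and "open" are said of these compounds alone.

In a functional assay on KB cells (Homo sapiens) for antiproliferative activity, read by sulforhodamine B assay, with a stated time of 3 days (a lower number here means that less compound is needed, a higher number that more compound is needed for the effect), compound 1 (`CCC1=C(O)c2c(oc(-c3ccc(O)cc3)cc2=O)C(CC)(CC)C1=O`) gives 20.6 uM as its reading, and compound 2 (`CCC1=C(O)c2c(oc(-c3ccc(C)c(Cl)c3)cc2=O)C(CC)(CC)C1=O`) gives 39 uM as its reading. Among the measured compounds shown here, these two readings lie within the scatter of each other, so compound 2 stands level with its only measured neighbour. Compound 3 (`CCC1=C(O)c2c(oc(-c3ccc(C)c(F)c3)cc2=O)C(CC)(CC)C1=O`) has fluoro in place of chloro on an aromatic carbon, ortho to a methyl group and meta to a large group: fluoro in place of chloro on an aromatic carbon is the whole change. For the measured compounds named here, only one measured step bears on it, a 1.9-fold higher number from compound 1 to compound 2 (0.28 log units; within the scatter), where 3-chloro-4-methylphenyl replaced 4-hydroxyphenyl. Going by the values given here, no measured pair tests the halogen directly. No step beyond the scatter is therefore expected in this assay for this smaller change. The expected shift is a 1.2-fold lower number from compound 2 to compound 3 (0.07 log units; within the scatter) in this series. For compound 3 the estimate is 33 uM with an expected range of 16 uM to 65 uM in this assay.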

Compound 3, concentration for half-maximal effect: 28.1 uM
Compound 3: the middle estimate sits 1.2-fold (0.07 log units) above what was measured; the range from low to high includes it.
By their numbers in this assay, from the lowest: compounds 1, 3 and 2 (each within the scatter of the next).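

In (this assay) the halogen on the aromatic carbon ortho to a methyl group now has a direct test, and the exchange of chloro for fluoro gives (a 1.4-fold lower number from compound 2 to compound 3 (0.14 log units; within the scatter)). Chloro and fluoro are therefore not told apart at this position in this series. The fluoro compound also stays level with the hydroxy compound, with 3-fluoro-4-methylphenyl in place of 4-hydroxyphenyl giving (a 1.4-fold higher number from compound 1 to compound 3 (0.13 log units; within the scatter)), so none of the three aryl groups shown separates from the others in (this assay). Still open, as far as these compounds go, is whether an amine or a carboxylic acid at this aromatic carbon, or a longer chain such as propyl in place of the methyl group, would move the reading beyond the scatter. No evidence is at hand that would explain the readings of these three compounds.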